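This account rests on a few compounds, and the source may have more. Where it says the series, first, only, none or still open, it means among the compounds named here.

Measured in a functional assay on DU-145 cells (Homo sapiens) for antiproliferative activity, read by MTT assay, with a stated time of 72 h; a lower number here means a stronger inhibitor, a higher number a weaker inhibitor:
Compound 1 `CN(c1ccccc1)S(=O)(=O)C1CC2OC1C(c1ccc(NC(=O)CCCCCCC(=O)O)cc1)=C2c1ccc(O)cc1`: > 100000 nM
Compound 2 `CCN(c1ccccc1)S(=O)(=O)C1CC2OC1C(c1ccc(NC(=O)CCCCCCC(=O)O)cc1)=C2c1ccc(O)cc1`: > 100000 nM

The entry for compound 1, > 100000 nM, is a limit of the assay and not a number. The entry for compound 2, > 100000 nM, is also only a limit. That is the whole picture so far: the limit of > 100000 nM in this assay, at which 2 of the 2 values shown sit.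

Compound 3 `CCN(c1cccc(OC)c1)S(=O)(=O)C1CC2OC1C(c1ccc(NC(=O)CCCCCCC(=O)O)cc1)=C2c1ccc(O)cc1` differs from compound 2 by one change, phenyl to 3-methoxyphenyl: methoxy in place of hydrogen on an aromatic carbon. Going by the values given here, the one measured step, a step that the two limits leave unreadable from compound 1 to compound 2, sits at a different place on the molecule, methyl in place of hydrogen on a saturated chain carbon bound to a sulfonamide nitrogen, and it gives no size to carry over. No step beyond the scatter is therefore expected in this assay, and another limit is the likeliest reading. The expected step is a number no higher from compound 2 to compound 3 (the limit leaves the size open). For compound 3 the estimate is 100000 nM, with an expected range of 40000 nM to 200000 nM.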

Compound 3, half-maximal inhibitory concentration: 71100 nM
For compound 3 the middle estimate is 1.4-fold (0.15 log units) above the measured one, within the range that was stated.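

Going by these compounds alone, of the three compounds, only compound 3 gives a number in this assay rather than a limit of the assay, so the aromatic ring on the sulfonamide nitrogen is the first place here where a change can be given any size. Methoxy in place of hydrogen on an aromatic carbon gives an at least 1.4-fold lower number from compound 2 to compound 3 (0.14 log units; that floor lies within the scatter) and the exchange of methyl(phenyl)amino for ethyl(3-methoxyphenyl)amino gives an at least 1.4-fold lower number from compound 1 to compound 3 (0.14 log units; that floor lies within the scatter) and neither goes beyond a floor. Both sizes stay open and the step between compound 1 and compound 2 cannot be read, for one shared reason: the limit of > 100000 nM in this assay, at which 2 of the 3 values shown sit.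

The compounds shown leave open how a hydroxyl or an amine on that ring would read, and whether methoxy on another carbon of the ring would read the same. They also leave open what a propyl chain in place of the ethyl would do with the methoxy kept.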